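A few compounds are considered here, and "the series" means these few. Any claim that something is new, unique, unknown or untested is made for them only; others in the source may bear on it.

Measured in an ADME assay on L02 cells (Homo sapiens) for cytotoxicity, read by MTT assay, with a stated time of 72 h; on this read-out higher numbers stand for weaker inhibition and lower numbers for stronger inhibition:
- compound 1 `CCC/C=C/C(=O)Nc1cccc(Oc2nc(Nc3cccc(OC)c3)nc3c2CSCC3)c1`: > 50000 nM
- compound 2 `CCC/C=C/C(=O)Nc1cccc(Oc2nc(Nc3cccc(C#N)c3)nc3c2CSCC3)c1`: > 50000 nM
- compound 3 `C=CC(=O)Nc1cccc(Oc2nc(Nc3ccc(OC)cc3)nc3c2CSCC3)c1`: > 50000 nM

All three entries are limits of the assay and not numbers, as the limit of > 50000 nM in this assay, at which 3 of the 3 values shown sit, records. Compound 3 stands at the limit of > 50000 nM in this assay. Compound 4 `CCC/C=C/C(=O)Nc1cccc(Oc2nc(Nc3ccc(OC)cc3)nc3c2CSCC3)c1` differs from it as follows: pent-1-en-1-yl in place of vinyl on a carbonyl carbon. Going by the values given here, the only measured step is a step that the two limits leave unreadable from compound 1 to compound 2, which concerns cyano in place of methoxy and so does not bear on this change. Compound 1 also carries pent-1-en-1-yl on a carbonyl carbon, and its > 50000 nM is a limit. Compound 2 carries that group too, and its > 50000 nM is also a limit. No step beyond the scatter is therefore expected, and the expected a number no higher from compound 3 to compound 4 (the limit leaves the size open) is small. For compound 4 the estimate is 50000 nM, with an expected range of 25000 nM to 100000 nM.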

Compound 4, half-maximal inhibitory concentration: > 50000 nM
Compound 4 ended at the assay's limit (the forecaster's own chance of this, stated with the estimate: 90%); the middle value sits exactly at the limit.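

Going by these compounds alone, no step to compound 4 from compound 1, compound 2 or compound 3 can be read, as all four stand at a limit and not a number: the limit of > 50000 nM in this assay, at which 4 of the 4 values shown sit. The compounds shown leave open whether any of these changes alters the read-out at all.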